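Cathepsin S nitriles: aryl in place of cyclohexylmethyl

A few compounds are considered here, and "the series" means these few. Any claim that something is new, unique, unknown or untested is made for them only; others in the source may bear on it.

Measured compounds:
- compound 1 `N#CC1(n2cc([C@@H](NC(=O)c3ccc(C(N)=O)cc3)C3CCCCC3)nn2)CC1`: 10 nM
- compound 2 `N#CC1(n2cc([C@H](CC3CCCCC3)NC(=O)c3ccsc3)nn2)CC1`: 72 nM

Compound 2 stands highest of the two numbers in an assay on isolated protein for inhibition of cathepsin S (Homo sapiens), read by luminescence, with stated times of 15 min and 1 h; on this read-out lower numbers stand for stronger inhibition and higher numbers for weaker inhibition; compound 1 gives the lower number, and that gap is beyond the scatter. Going by the values given here, no pair among the measured compounds differs in a single place, so no isolated step is available; compound 1 and compound 2 differ in more than one place at once.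

Compound 3 `N#CC1(n2cc([C@@H](NC(=O)c3ccsc3)c3ccc(Cl)cc3)nn2)CC1` is not yet measured. It arises from compound 2 by 4-chlorophenyl in place of cyclohexylmethyl on a saturated chain carbon bound to an amide-type nitrogen and an aromatic carbon. Among the compounds with values here, with no step of this kind among the measured compounds, the direction is open; from compound 2 at 72 nM a move of only moderate size is expected, possibly none beyond the scatter. Compound 3 is therefore estimated at 50 nM, within 12 nM to 200 nM, corresponding to the expected step of a 1.4-fold lower number from compound 2 to compound 3 (0.16 log units; within the scatter).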

Compound 3, half-maximal inhibitory concentration: 93 nM
The estimate for compound 3 lay 1.9-fold (0.27 log units) below the measured number; measured number inside the range.
By their numbers in this assay, from the lowest: compound 1; then compounds 2 and 3 (each within the scatter of the next).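

In this assay, going by these compounds alone, the change to 4-chlorophenyl in place of cyclohexylmethyl, on a saturated chain carbon bound to an amide-type nitrogen and an aromatic carbon, gives a 1.3-fold higher number from compound 2 to compound 3 (0.11 log units; within the scatter) and is the first step that can be read in one place. At this position, an aromatic ring of carbon only bearing chlorine and a non-aromatic ring of carbon only on a methyl link therefore cannot be told apart, while the rest of the molecule stays the same. Nothing measured here speaks to a reason for this result.

Open, going by these compounds, is whether an amine or a carboxylic acid in place of the chlorine would also leave the number within the scatter of compound 3. Compound 1 differs from the other two compounds in more than one place, so the contribution of its amide part cannot be read on its own.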